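The source may report more compounds than this note shows. Statements on the series, on what has been measured and on what is new or still open speak of the compounds shown alone.

Of the compounds shown here, two that share one core have been measured in an assay on AV12 cells for binding affinity to Neuropeptide Y receptor type 1 (Homo sapiens); a higher number here means a weaker inhibitor, a lower number a stronger inhibitor. Compound 1 `Cc1cccc2c1nc(COc1ccc(Cl)cc1)n2CCCC1CCN(CCC(C)C)CC1` gives 11 nM in this assay, and compound 2 `Cc1cccc2c1nc(COc1ccc(Cl)cc1)n2CCCC1CCN(CC(=O)N2CCCCC2)CC1` gives 136 nM. Among the compounds with values here, of the two numbers, compound 2 has the higher one, and the only step between them, a 12-fold higher number from compound 1 to compound 2 (1.09 log units; beyond the scatter), is the large one in which a (piperidin-1-yl)carbonyl took the place of an isobutyl on a saturated chain carbon bound to an amine nitrogen in a ring.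

Compound 3 `Cc1cccc2c1nc(COc1ccc(Cl)cc1)n2CCCC1CCN(C(=O)CCN2CCCCC2)CC1` is not yet measured. It differs from compound 2 as follows: (2-(piperidin-1-yl)ethyl)carbonyl in place of ((piperidin-1-yl)carbonyl)methyl on an amine nitrogen in a ring. Within the data shown here, the one measured step concerned a different change at a nearby position, so no step in hand speaks directly to this exchange; the only guide is that both compound 2 and compound 3 carry a six-membered ring with one nitrogen at the end of a short arm from the same ring nitrogen. With so little to go on, compound 3 is expected to give a number close to that of compound 2, a step of a 1.4-fold lower number from compound 2 to compound 3 (0.13 log units; within the scatter) that need not exceed the scatter. The estimate for compound 3 in this assay is therefore 100 nM, with a range from 25 nM to 400 nM.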

Compound 3, inhibition constant: 260 nM
Estimate against measurement, compound 3: 2.6-fold (0.41 log units) below; measured number inside the range.
By their numbers in this assay, from the lowest: compound 1; then compounds 2 and 3 (each within the scatter of the next).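

In this assay, exchanging the ((piperidin-1-yl)carbonyl)methyl of compound 2 for the (2-(piperidin-1-yl)ethyl)carbonyl of compound 3 on the amine nitrogen in a ring gives a 1.9-fold higher number from compound 2 to compound 3 (0.28 log units; within the scatter), so these two arms cannot be told apart here, although the carbonyl stands directly on that ring nitrogen only in compound 3. Set against the isopentyl of compound 1, the new arm gives a 24-fold higher number from compound 1 to compound 3 (1.37 log units; beyond the scatter), a large step in the same direction as a 12-fold higher number from compound 1 to compound 2 (1.09 log units; beyond the scatter), so both arms that carry a carbonyl and a piperidin-1-yl ring give clearly higher numbers than the plain chain, however these two parts are arranged. Nothing measured here bears on the reason for these numbers.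

The compounds shown leave open whether the carbonyl or the piperidin-1-yl ring goes with the higher numbers, as the two always occur together in them. A 2-(piperidin-1-yl)ethyl chain with no carbonyl, or a carbonyl bearing a plain pentyl chain, would separate the two parts, and a morpholine or a dimethylamino group in place of the ring would test how much that ring matters.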